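Replacing a Chlorophenyl with a Nitrobenzyl on the Pyrazole Acid

A few compounds are considered here, and "the series" means these few. Any claim that something is new, unique, unknown or untested is made for them only; others in the source may bear on it.

Compound 1 `Cc1nn(-c2nc(-c3ccc(Cl)c(Cl)c3)c(SC(C)C)s2)c(C(=O)O)c1-c1cnn(C)c1`: 6800 nM
Compound 2 `Cc1nn(-c2nc(-c3ccc(Cl)c(Cl)c3)c(SC(C)C)s2)c(C(=O)O)c1-c1cccc(Cl)c1`: 13600 nM

In a functional assay on BJAB cells (Homo sapiens) for antiproliferative activity, with a stated time of 4 days (a lower number here means that less compound is needed, a higher number that more compound is needed for the effect), compound 2 gives the highest of the two numbers, with compound 1 nearest to it; the step of a 2.0-fold higher number from compound 1 to compound 2 (0.30 log units; within the scatter) lies within the scatter. Compound 3 `Cc1nn(-c2nc(-c3ccc(Cl)c(Cl)c3)c(SC(C)C)s2)c(C(=O)O)c1Cc1ccccc1[N+](=O)[O-]` carries the change (2-nitrobenzyl in place of 3-chlorophenyl on an aromatic carbon). Among the measured compounds shown here, the only step that bears on this site is the one from compound 1 to compound 2, and it was within the scatter, so no shift beyond the scatter is expected, the step of a 1.1-fold higher number from compound 2 to compound 3 (0.04 log units; within the scatter) being small. Compound 3 is therefore estimated at 15000 nM, with a range from 5000 nM to 45000 nM.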

Compound 3, half-maximal effective concentration: 20000 nM
Compound 3: middle estimate off by 1.3-fold (0.12 log units), on the low side, within the range that was stated.
By their numbers in this assay, from the lowest: compounds 1, 2 and 3 (each within the scatter of the next, the first and the last beyond it).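

In this assay, 2-nitrobenzyl in place of 3-chlorophenyl at this position gives a 1.5-fold higher number from compound 2 to compound 3 (0.17 log units; within the scatter) and so cannot be told apart from it. Set against 1-methyl-1H-pyrazol-4-yl, the same group gives a 2.9-fold higher number from compound 1 to compound 3 (0.47 log units; beyond the scatter) as the first step at this position to pass the scatter, although the change is modest. Nothing available explains either step.

Still open, on these data alone, is whether a plain benzyl matches 2-nitrobenzyl, and whether an aminomethyl group or a longer carbon chain at this position would give a clearly lower number.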